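The source may report more compounds than this note shows. Statements on the series, on what has been measured and on what is new or still open speak of the compounds shown alone.

Measured compounds:
compound 1 `COc1ccc(F)cc1CNCCCNc1ccnc2cc(Cc3ccc(C#N)cc3)ccc12` gives 23 10^-6 cm/s
compound 2 `CC(C)(C)c1ccc(Oc2ccc3c(NCCCNCc4ccco4)ccnc3c2)cc1` gives 317 10^-6 cm/s
compound 3 `COc1cccc(CNCCCNc2ccnc3cc(Cc4ccc(C#N)cc4)ccc23)c1O` gives 23 10^-6 cm/s

All three were measured in an ADME assay for permeability, using PAMPA, with a stated time of 30 min, at pH 7.4; a higher number here means that the compound crosses the layer faster, a lower number that the compound crosses the layer more slowly. Compound 1 stands level with compound 3 at the digits shown, and these two are the lowest of the three numbers; compound 2 sits far above them. Within the data shown here, the one step between compounds that differ in a single place, no change at the digits printed from compound 1 to compound 3 (within the scatter), concerns the group on the saturated chain carbon bound to the amine nitrogen and leaves the read-out unchanged within the scatter.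

Compound 4 `COc1ccc(F)cc1CNCCCNc1ccnc2cc(-c3cccc4ccccc34)ccc12` has not yet been measured in this assay. It differs from compound 1 in one place: naphthalen-1-yl in place of 4-cyanobenzyl on an aromatic carbon. Among the measured compounds shown here, no measured step touches this position, so the single step on record does not bear on it directly. For the measured compounds named here, what the other numbers show is that compound 2, the only compound without the 4-cyanobenzyl group, gives 317 10^-6 cm/s, well above compound 1. For compound 4 the expected step is therefore an increase, a 3.5-fold higher number from compound 1 to compound 4 (0.54 log units; beyond the scatter), and the estimated value is 80 10^-6 cm/s with a range from 30 10^-6 cm/s to 250 10^-6 cm/s.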

Compound 4, apparent permeability: 237 10^-6 cm/s
The estimate for compound 4 lay 3.0-fold (0.47 log units) below the measured number, and the stated range covers the measured number.
By their numbers in this assay, from the lowest: compounds 1 and 3 (each within the scatter of the next); then compounds 4 and 2 (each within the scatter of the next).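

In this assay, the aromatic carbon that carries 4-cyanobenzyl in compound 1 turns out to be a place where the read-out moves strongly: putting naphthalen-1-yl there gives a 10-fold higher number from compound 1 to compound 4 (1.01 log units; beyond the scatter). Among these compounds, the only earlier single-place step, no change at the digits printed from compound 1 to compound 3 (within the scatter), concerned the group on the saturated chain carbon, so the earlier compounds tied no change in the number to this aromatic carbon. Nothing available accounts for the size of the new step.

The step exchanges the whole group at once, so the compounds shown do not separate the loss of the nitrile from the gain of the second aromatic ring. As far as these compounds go, how plain benzyl or 4-cyanophenyl would read at this position remains open, and either would help to divide the step between those parts.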